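Swapping a Difluorophenyl Amide for a Fluoropyridinyl Amide

This account rests on a few compounds, and the source may have more. Where it says the series, first, only, none or still open, it means among the compounds named here.

Of the compounds shown here, three sharing one core have been measured in an ADME assay on LLC-MK2 cells (Macaca mulatta) for cytotoxicity, read by spectrophotometry and crystal violet staining, with a stated time of 4 days; on this read-out higher numbers stand for lower toxicity in this test and lower numbers for higher toxicity in this test. Compound 1 `CC(C)n1ncc2c(C(=O)Nc3cccc(F)c3F)cc(-c3cccs3)nc21` gives 75000 nM. Compound 2 `CC(C)n1ncc2c(C(=O)Nc3ccccc3F)cc(-c3ccncc3)nc21` gives 45000 nM, and compound 3 `CC(C)n1ccc2c(C(=O)Nc3cccnc3)cc(-c3cccs3)nc21` gives 25000 nM. Among these, compound 1 has the highest number; the gap to compound 2 lies within the usual scatter, while the gap to compound 3 lies beyond it. No pair of these compounds differs in a single place, so no step between measured compounds can be read off.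

The next compound, compound 4 `CC(C)n1ncc2c(C(=O)Nc3ccc(F)cn3)cc(-c3cccs3)nc21`, differs from compound 1 in one place: 5-fluoropyridin-2-yl in place of 2,3-difluorophenyl on an amide-type nitrogen. Going by the values given here, nothing measured so far isolates this change, so its effect in this assay is open. Compound 4 is expected to show a step of a 1.4-fold lower number from compound 1 to compound 4 (0.13 log units; within the scatter), that is, a number a little lower than that of compound 1 but within the usual scatter, since the two compounds bearing a pyridine ring, compound 2 with 45000 nM and compound 3 with 25000 nM, sit somewhat lower. The estimate for compound 4 is 55000 nM, with a range from 25000 nM to 120000 nM.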

Compound 4, half-maximal cytotoxic concentration: > 200000 nM
Compound 4: a limit, no number; the forecaster's own chance of this, stated with the estimate: 20%; middle value at least 3.6-fold (0.56 log units) away from the limit.
By their numbers in this assay, from the lowest: compounds 3, 2 and 1 (each within the scatter of the next, the first and the last beyond it). At a limit, above all of these: compound 4.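

In this assay, compound 4 gives > 200000 nM, which is a limit of the assay and not a number. Placing 5-fluoropyridin-2-yl in place of 2,3-difluorophenyl on the amide-type nitrogen brings an at least 2.6-fold higher number from compound 1 to compound 4 (0.42 log units; beyond the scatter), the first single-place step here, showing that this position bears on the read-out and that this change moves it towards lower toxicity in this test. The full size of the step cannot be read because compound 4 stands at a limit: the limit of > 200000 nM in this assay, at which 1 of the 4 values shown sits.

The change brings in a ring nitrogen and removes a fluorine at once, and the compounds shown do not separate the two. Also open, on these data alone, is how an unsubstituted phenyl or a pyridin-2-yl without fluorine would read on this amide-type nitrogen.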